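Methyl for methoxy: notes on stability in the series

A few compounds are considered here, and "the series" means these few. Any claim that something is new, unique, unknown or untested is made for them only; others in the source may bear on it.

In an ADME assay on microsomes from liver (Mus musculus) for metabolic stability, with a stated time of 10 min, tested at 1 uM (on this read-out higher numbers stand for a more stable compound and lower numbers for a less stable compound), the measured compounds stand as follows
compound 1 `COc1c(-c2ccc(C(F)(F)F)cc2Cl)ccc2c1cnn2[C@@H](CC(C)C)c1ccc(C(=O)NCCC(=O)O)cc1` gives 87%
compound 2 `Cc1cc2c(cnn2[C@@H](CC(C)C)c2ccc(C(=O)NCCC(=O)O)cc2)cc1-c1ccc(C(F)(F)F)cc1Cl` gives 99%

Compound 1 holds the lower of the two numbers, and compound 2 lies above it by more than the usual scatter. The next step leads from compound 1 to compound 3 `Cc1c(-c2ccc(C(F)(F)F)cc2Cl)ccc2c1cnn2[C@@H](CC(C)C)c1ccc(C(=O)NCCC(=O)O)cc1`, with methyl in place of methoxy on an aromatic carbon, ortho to a 2-chloro-4-(trifluoromethyl)phenyl group (methyl in place of methoxy on an aromatic carbon). Among the compounds with values here, no measured pair shows this change on its own, so the expectation rests on thin ground. Within the data shown here, the only guide is that both numbers sit high on the scale, with compound 1 at 87% and compound 2 at 99% as the two reference points. In this assay a small upward move is therefore expected, not beyond the scatter. The expected change a number 5 percentage points higher from compound 1 to compound 3 (within the scatter) is of that modest size. Compound 3 is estimated at 92% (expected range 82% to 100%).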

Compound 3, percent of the compound remaining: 121%
Compound 3: the middle estimate sits 29 percentage points below what was measured; the whole stated range lies below it.
By their numbers in this assay, from the lowest: compound 1; then compound 2; then compound 3.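

Within the data shown here, at this place, ortho to a 2-chloro-4-(trifluoromethyl)phenyl group, methyl in place of methoxy is the first single change that can be read, and in this assay it gives a large step (a number 34 percentage points higher from compound 1 to compound 3 (beyond the scatter)). The percent remaining for compound 3 (121%) exceeds the whole of the compound, so the number is safer read as no detectable loss over the stated time than as an exact measure of the step. This is one pair on one read-out, and nothing at hand explains the step.

Going by these compounds, it remains open whether other groups at this place, such as an ethyl chain, a fluorine, a hydroxyl or an amine, would stand with methyl or with methoxy in this assay. Also open, on these data alone, is whether the same exchange on another aromatic carbon of the shared core, or with a nitrile on the phenyl group in place of trifluoromethyl, would give a step of similar size.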